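The source may hold more compounds than are shown below. What is called first, only, known or untested is meant among the compounds shown, and "the series" means these compounds.

Two members of the series have been measured for cytotoxicity. Compound 1 `Cn1c(C[S+]([O-])c2ccccc2)nc2c(Cn3ccnc3)c(O)ccc21` gives 557000 nM in an ADME assay on HepG2 2.2.15 cells (Homo sapiens) for cytotoxicity, with a stated time of 9 days; a lower number here means that less compound is tolerated, a higher number that more compound is tolerated. Compound 2 `COc1cccc(SCc2nc3c(Cn4ccnc4C)c(O)ccc3n2C)c1` gives 103000 nM in this assay, the lowest of the two numbers; compound 1 sits higher by a margin beyond the scatter, so of these two compound 2 is the one of which less is tolerated by the cells. Going by the values given here, no pair of measured compounds differs in one place only, so no single structural step has yet been read against this assay.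

Compound 3 `COc1ccc(SCc2nc3c(Cn4ccnc4C)c(O)ccc3n2C)cc1` is the next compound to be measured. It differs from compound 2 in one place: 4-methoxyphenyl in place of 3-methoxyphenyl on a sulfur. The two compounds share every atom and differ only in where the methoxy group sits on the phenyl ring carried by the sulfur. Nothing in the measured pair speaks to such a change. The expectation is therefore a step from compound 2 to compound 3 of a 1.0-fold lower number from compound 2 to compound 3 (0.01 log units; within the scatter), that is, none beyond the scatter. For compound 3 the estimated value in this assay is 100000 nM, with a range from 40000 nM to 250000 nM.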

Compound 3, half-maximal cytotoxic concentration: 164000 nM
Estimate against measurement, compound 3: 1.6-fold (0.21 log units) below, and the stated range covers the measured number.
By their numbers in this assay, from the lowest: compounds 2 and 3 (each within the scatter of the next); then compound 1.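

Placing the methoxy group differently on the phenyl ring carried by the sulfur gives the first single-place reading in this assay, a 1.6-fold higher number from compound 2 to compound 3 (0.20 log units; within the scatter), so 3-methoxyphenyl and 4-methoxyphenyl cannot be told apart here. For these two groups, the place of the methoxy group on this ring therefore makes no difference beyond the scatter to the amount of compound the cells tolerate, though this rests on one pair and says nothing about other groups on the sulfur. No measured information on the compounds bears on why the pair reads alike.

Still open, on these data alone, is whether a group of another kind on this phenyl ring, such as an amine or a carboxylic acid in place of the methoxy group, would stay equally close to compound 2 and compound 3. Compound 1 differs from both in more than one place, so its higher number cannot yet be assigned to any single part of the structure, and the separate contributions of the groups on the sulfur and of the methyl on the imidazole remain unresolved.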